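Swapping oxolan-2-yl for 2-cyclopentylethyl on the sulfonyl side chain

The source may report more compounds than this note shows. Statements on the series, on what has been measured and on what is new or still open speak of the compounds shown alone.

In a functional assay, read by fluorescence and spectrophotometry, with a stated time of 1 h (on this read-out higher numbers stand for an effect only at larger amounts of compound and lower numbers for an effect already at smaller amounts), compound 1 (`O=S(=O)(/C=C/c1ccc(O)c(O)c1)CCCCCCCO`) gives 5900 nM and compound 2 (`O=S(=O)(/C=C/c1ccc(O)c(O)c1)CC1CCCO1`) gives 10500 nM. For the measured compounds named here, compound 2 therefore stands within the scatter of its only measured neighbour. Compound 3 (`O=S(=O)(/C=C/c1ccc(O)c(O)c1)CCCC1CCCC1`) carries 2-cyclopentylethyl in place of oxolan-2-yl on a saturated chain carbon bound to a sulfonyl sulfur. The change is 2-cyclopentylethyl in place of oxolan-2-yl on a saturated chain carbon bound to a sulfonyl sulfur. Going by the values given here, only one measured step bears on it, a side-chain exchange at the same place: a 1.8-fold higher number from compound 1 to compound 2 (0.25 log units; within the scatter). On that single precedent, no step beyond the scatter is expected in this assay. The expected step is a 1.4-fold lower number from compound 2 to compound 3 (0.15 log units; within the scatter). For compound 3 the estimate is 7500 nM, with an expected range of 2800 nM to 20000 nM.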

Compound 3, half-maximal effective concentration: 6300 nM
The estimate for compound 3 lay 1.2-fold (0.08 log units) above the measured number, and the stated range covers the measured number.
By their numbers in this assay, from the lowest: compounds 1, 3 and 2 (each within the scatter of the next).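

Replacing the ring with an oxygen by a carbon-only ring, 2-cyclopentylethyl in place of oxolan-2-yl, gives a 1.7-fold lower number from compound 2 to compound 3 (0.22 log units; within the scatter) in this assay, so this read-out does not separate these two side chains. Cyclopentyl in place of 4-hydroxybutyl gives a 1.1-fold higher number from compound 1 to compound 3 (0.03 log units; within the scatter), which shows that a side chain without a hydroxyl or ring oxygen also stays within the scatter of the hydroxyhexyl compound. No supporting data explain this result.

On these data alone, whether an amine, a carboxylic acid or a methyl group at this place would give a step beyond the scatter remains open.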